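Removing the Benzyloxy Group from a Weak Dioxygenase Inhibitor

This account rests on a few compounds, and the source may have more. Where it says the series, first, only, none or still open, it means among the compounds named here.

Measured compounds:
compound 1 `O=[N+]([O-])c1cc(OCc2ccccc2)ccc1CNc1cc(C(F)(F)F)cc2[nH]ncc12`: 97000 nM
compound 2 `FC(F)(F)c1cc(NCc2cccc3sccc23)c2cn[nH]c2c1`: > 100000 nM
compound 3 `OC1CCCC(Nc2cccc(CNc3cc(C(F)(F)F)cc4[nH]ncc34)c2)C1`: > 100000 nM

Three compounds sharing one core were tested in an assay for inhibition of Tryptophan 2,3-dioxygenase (Homo sapiens), with stated times of 10 min and 60 min; a lower number here means a stronger inhibitor, a higher number a weaker inhibitor. Among the measured compounds shown here, compound 1 gives 97000 nM, the only real number in the set. Compound 2 reaches only the limit of the assay, > 100000 nM. Compound 3 likewise reaches only a limit, > 100000 nM. So compound 1 stands alone with a measurable value, while the other two sit at the limit of > 100000 nM in this assay, at which 2 of the 3 values shown sit.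

Compound 4 `O=[N+]([O-])c1ccccc1CNc1cc(C(F)(F)F)cc2[nH]ncc12` differs from compound 1 in one place: hydrogen in place of benzyloxy on an aromatic carbon. For the measured compounds named here, no measured pair shows what such a change does here, so the direction is uncertain; given how weak the whole set is, a small step toward weaker binding, or none beyond the scatter, is expected. Compound 4 is estimated at 150000 nM, between 40000 nM and 500000 nM. The expected step is a 1.5-fold higher number from compound 1 to compound 4 (0.19 log units; within the scatter).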

Compound 4, half-maximal inhibitory concentration: 2550 nM
Beside the measured number, compound 4's estimate is 59-fold (1.77 log units) above it; the measured number lies below the stated range.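

In this assay, replacing benzyloxy with hydrogen on this aromatic carbon, para to a large group, gives a 38-fold lower number from compound 1 to compound 4 (1.58 log units; beyond the scatter). In this pair, then, the benzyloxy group is not needed for inhibition, and bare hydrogen gives the stronger inhibitor. Compound 4 is also the one compound here that stands well clear of the assay's limit: the limit of > 100000 nM in this assay, at which 2 of the 4 values shown sit.

From the compounds shown here alone, whether a small group at this position, such as methoxy or an amine, would match hydrogen remains open. What the nitro group contributes to compound 4, and why the step is so large, also stay unknown.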